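Replacing the 2-hydroxyphenyl of Compound 1 with 3-fluorophenyl

The source may hold more compounds than are shown below. What is called first, only, known or untested is meant among the compounds shown, and "the series" means these compounds.

Compound 1 `O=C(/C=C\c1ccccc1O)N1N=C(c2ccncc2)OC1c1c[nH]c2ccccc12` was tested in an ADME assay on PANC-1 cells (Homo sapiens) for cytotoxicity, read by MTT assay, with a stated time of 48 h; a higher number here means a weaker inhibitor of growth, a lower number a stronger inhibitor of growth. In this assay compound 1 reaches only a limit, > 30 ug/mL, and no number is known. Compound 2 `O=C(/C=C\c1cccc([N+](=O)[O-])c1)N1N=C(c2ccncc2)OC1c1c[nH]c2ccccc12` likewise gives in this assay only a limit, > 30 ug/mL. The step that the two limits leave unreadable from compound 1 to compound 2 is therefore unreadable, since the limit of > 30 ug/mL in this assay, at which 2 of the 2 values shown sit, covers both compounds. Compound 3 `O=C(/C=C\c1cccc(F)c1)N1N=C(c2ccncc2)OC1c1c[nH]c2ccccc12` has not yet been measured in this assay. It differs from compound 1 thus: 3-fluorophenyl in place of 2-hydroxyphenyl on a double-bonded chain carbon bound to a double-bonded chain carbon. Among the measured compounds shown here, the one measured step that bears on it exchanges the same 2-hydroxyphenyl at the same place for another substituted phenyl, but its size cannot be read, so no direction is known. The step that the limit leaves unreadable from compound 1 to compound 3 is accordingly expected to stay within the scatter. Compound 3 is estimated at 40 ug/mL, in the range 15 ug/mL to 100 ug/mL, and is expected most likely to be reported again only as a limit.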

Compound 3, concentration for 50% growth inhibition: > 30 ug/mL
Compound 3 was reported as a limit (the forecaster's own chance of this, stated with the estimate: 75%); the middle value is on the limit's open side.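

In this assay, among the compounds shown here, compound 3 is again reported only as a limit, so no step among compound 1, compound 2 and compound 3 can be read. The compounds shown leave open whether 2-hydroxyphenyl, 3-nitrophenyl or 3-fluorophenyl makes any difference in this assay at all.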